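Dichlorostyryl lactones: pendant aryl changes and reductase inhibition

This account rests on a few compounds, and the source may have more. Where it says the series, first, only, none or still open, it means among the compounds named here.

Measured so far:
compound 1 `COc1ccc(-c2cc(Cl)cc(Cl)c2/C=C/[C@@H]2C[C@@H](O)CC(=O)O2)cc1` 470 nM
compound 2 `O=C1C[C@H](O)C[C@@H](/C=C/c2c(Cl)cc(Cl)cc2-c2ccccc2)O1` 80 nM
compound 3 `Cc1ccccc1-c1cc(Cl)cc(Cl)c1/C=C/[C@@H]1C[C@@H](O)CC(=O)O1` 370 nM

In an assay for inhibition of 3-hydroxy-3-methylglutaryl-coenzyme A reductase (Rattus norvegicus) (on this read-out lower numbers stand for stronger inhibition and higher numbers for weaker inhibition), compound 3 stands second highest of the three; compound 1 sits within the scatter of it, compound 2 clearly lower, as a 4.6-fold higher number from compound 2 to compound 3 (0.67 log units; beyond the scatter) shows. Compound 4 `O=C1C[C@H](O)C[C@@H](/C=C/c2c(Cl)cc(Cl)cc2CCc2ccccc2)O1` carries phenethyl in place of 2-methylphenyl on an aromatic carbon. Among the measured compounds shown here, no measured step covers swapping the biaryl link for a two-carbon chain; the only steps on this aromatic carbon's substituent are a 5.9-fold lower number from compound 1 to compound 2 (0.77 log units; beyond the scatter) and a 4.6-fold higher number from compound 2 to compound 3 (0.67 log units; beyond the scatter), both modest, and both concern substitution on the pendant ring rather than how it is attached. For compound 4 a step near zero is therefore expected, a 1.1-fold higher number from compound 3 to compound 4 (0.03 log units; within the scatter), with wide uncertainty. Compound 4 is estimated at 400 nM, range 100 nM to 1600 nM.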

Compound 4, half-maximal inhibitory concentration: 430 nM
Compound 4: the middle estimate sits 1.1-fold (0.03 log units) below what was measured; low and high end bracket the measured number.
By their numbers in this assay, from the lowest: compound 2; then compounds 3, 4 and 1 (each within the scatter of the next).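

Phenethyl on this aromatic carbon is the first change to how the pendant ring is attached, and it does not match the plain phenyl of the low-end compound (a 5.4-fold higher number from compound 2 to compound 4 (0.73 log units; beyond the scatter)). Against the substituted aryl groups, the chain stays within the scatter (a 1.2-fold higher number from compound 3 to compound 4 (0.07 log units; within the scatter); a 1.1-fold lower number from compound 1 to compound 4 (0.04 log units; within the scatter)). Nothing available explains these steps.

As far as these compounds go, whether a benzyl group, a longer chain ending in phenyl, or an amine within the chain would reach the number of compound 2 stays open. Substituents on the phenethyl ring also remain open.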